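The compounds below may be only part of what the source reports. "The series", "measured", "known", "first", "only" and "open" are said of these compounds alone.

Of the compounds shown here, three of closely related build have been tested for how strongly they damage a mouse cell line, in an ADME assay on J774.A1 cells (Mus musculus) for cytotoxicity, read by MTT assay, with a stated time of 72 h; on this read-out higher numbers stand for lower toxicity in this test and lower numbers for higher toxicity in this test. Compound 1, `Clc1ccc(COC(CCn2ccnc2)c2ccco2)c(Cl)c1`, gives 56200 nM in this assay. Compound 3, `Clc1cccc(COC(CCn2ccnc2)c2ccco2)c1`, gives 60200 nM in this assay, and compound 2, `Clc1cccc(COC(CCn2ccnc2)c2cccs2)c1`, gives 46000 nM in this assay. All three numbers lie close together, so none of them can be called more or less toxic than another on this evidence.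

The difference between the core of compound 1 and the core of compound 3 is not broken down here. Compound 2 arises from compound 3 by one change, (thiophen-2-yl in place of furan-2-yl on a saturated chain carbon bound to an oxygen on a saturated carbon and a saturated chain carbon), and this change made a 1.3-fold lower number from compound 3 to compound 2 (0.12 log units; within the scatter).

The unmeasured compound 4, `Clc1ccc(COC(CCn2ccnc2)c2cccs2)c(Cl)c1`, arises from compound 1 by the same change, (thiophen-2-yl in place of furan-2-yl on a saturated chain carbon bound to an oxygen on a saturated carbon and a saturated chain carbon). Going by the values given here, since both changes read the same word for word, including where they sit, the step seen from compound 3 to compound 2 is the only guide to what happens from compound 1 to compound 4. Because that step was a 1.3-fold lower number from compound 3 to compound 2 (0.12 log units; within the scatter), the expected step for compound 4 is a 1.3-fold lower number from compound 1 to compound 4 (0.12 log units; within the scatter), which is a small shift that may well be lost in the ordinary repeat scatter. The estimated value for compound 4 in this assay is therefore 43000 nM. The expected range for compound 4 runs from 25000 nM to 75000 nM.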

Compound 4, half-maximal cytotoxic concentration: 29700 nM
Compound 4: the middle estimate sits 1.4-fold (0.16 log units) above what was measured, within the range that was stated.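

On the core of compound 1, putting thiophen-2-yl in place of furan-2-yl gave a 1.9-fold lower number from compound 1 to compound 4 (0.28 log units; within the scatter) in this assay. Set beside the same change on the other core, this step does not differ from the earlier one by more than repeat measurements would be expected to: the same change on two cores in this assay, a 1.3-fold lower number (0.12 log units; within the scatter) from compound 3 to compound 2 and a 1.9-fold lower number (0.28 log units; within the scatter) from compound 1 to compound 4, 1.4-fold (0.16 log units) apart, within the scatter of two such steps. The change therefore carries across these two cores without any sign that the core alters its effect, but both steps lie within the scatter, so this shows neither that the change truly shifts toxicity in this test nor that the agreement would hold on a third core.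

The compounds shown carry only furan-2-yl and thiophen-2-yl at this place, so it remains open whether a phenyl ring, a pyridine ring or a simple alkyl group there would give a number clearly apart from these. As far as these compounds go, it also remains open whether the same change would behave alike on a core carrying an amine, a carboxylic acid or a longer chain.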